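A few compounds are considered here, and "the series" means these few. Any claim that something is new, unique, unknown or untested is made for them only; others in the source may bear on it.

In an ADME assay on H1-HeLa cells (Homo sapiens) for cytotoxicity, read by MTT assay, with a stated time of 3 days (on this read-out higher numbers stand for lower toxicity in this test and lower numbers for higher toxicity in this test), compound 1 `CNC(=O)c1cc(Oc2ccc3c(C)c(-c4noc(C5CC5)n4)sc3c2)ccn1` gives 6800 nM. Compound 2 `CNC(=O)c1cc(Oc2ccc(-c3noc(C)n3)cc2)ccn1` gives > 100000 nM, which is a limit of the assay and not a number. Compound 3 `CNC(=O)c1cc(Oc2ccc(-c3noc(CC(C)C)n3)cc2)ccn1` differs from compound 2 in one place: isopropyl in place of hydrogen on a saturated chain carbon bound to an aromatic carbon, so that methyl becomes isobutyl. Among the compounds with values here, no measured pair shows what this change does in this assay. Within the data shown here, the only firm number comes from compound 1 at 6800 nM, a different and larger molecule, so it offers only a loose guide. A small move toward lower numbers is expected, perhaps none beyond the usual scatter, and the reading may well stay at the limit. The estimated size of the change is an at least 1.4-fold lower number from compound 2 to compound 3 (0.15 log units; that floor lies within the scatter). For compound 3 the expected value is 70000 nM, with an estimated range of 20000 nM to 200000 nM.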

Compound 3, half-maximal cytotoxic concentration: 23400 nM
Beside the measured number, compound 3's estimate is 3.0-fold (0.48 log units) above it; the measured number falls inside the stated range.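

Within the data shown here, until now no measured pair covered this position, the saturated chain carbon bound to an aromatic carbon. Placing isopropyl there in place of hydrogen, so that methyl becomes isobutyl, gives an at least 4.2-fold lower number from compound 2 to compound 3 (0.63 log units; beyond the scatter) in this assay. Compound 3 thus gives a real number on the core it shares with compound 2, so a change at this one place is enough to move the read-out. Only a floor for the step can be read, and the true size may be larger, because compound 2 stands at a limit of the assay and not at a number: the limit of > 100000 nM in this assay, at which 1 of the 3 values shown sits.

Methyl and isobutyl alone cannot show a trend along this position. On these data alone, whether a longer straight chain, or a chain ending in an amine, would move the number the same way stays open.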